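This account rests on a few compounds, and the source may have more. Where it says the series, first, only, none or still open, it means among the compounds named here.

In a functional assay on Rec1 cells (Homo sapiens) for inhibition, read by luminescence and CellTiter-Glo, with a stated time of 72 h (on this read-out higher numbers stand for weaker inhibition and lower numbers for stronger inhibition), compound 1 `C/C=C/C(=O)Nc1ccc(Cn2nc(-c3ccc(Oc4ccccc4)cc3)cc2C(=O)O)cc1` gives 23600 nM and compound 2 `C=CC(=O)Nc1ccc(Cn2nc(-c3ccc(Oc4ccccc4)cc3)cc2C(=O)OCC)cc1` gives 2800 nM as the lower of the two numbers, a gap that lies beyond the usual scatter. Compound 2 therefore stands as the stronger inhibitor of this pair. Compound 3 `C/C=C/C(=O)Nc1ccc(Cn2nc(-c3ccc(Oc4ccccc4)cc3)cc2C(=O)OCC)cc1` has not yet been measured. It differs from compound 2 in a single place, where prop-1-en-1-yl stands in place of vinyl on a carbonyl carbon that also carries an amide-type nitrogen, a change counted as prop-1-en-1-yl in place of vinyl on a carbonyl carbon in this comparison. Among the compounds with values here, no measured pair shows this change on its own, so any expectation for it lacks a direct precedent. Taking compound 2 at 2800 nM as the reference, only a slight drift toward a higher number is expected in this assay, with no step beyond the scatter. The estimated step of a 1.4-fold higher number from compound 2 to compound 3 (0.15 log units; within the scatter) is expected to remain that small. Compound 3 is estimated to read about 4000 nM in this assay, with 1500 nM to 11000 nM as the expected range.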

Compound 3, half-maximal inhibitory concentration: 13100 nM
The estimate for compound 3 lay 3.3-fold (0.52 log units) below the measured number; the whole stated range lies below it.
By their numbers in this assay, from the lowest: compound 2; then compounds 3 and 1 (each within the scatter of the next).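

In this assay, within the data shown here, prop-1-en-1-yl in place of vinyl on a carbonyl carbon whose other neighbour is an amide-type nitrogen gives a 4.7-fold higher number from compound 2 to compound 3 (0.67 log units; beyond the scatter), the first direct reading at this position, and it shows that the read-out responds to this change even though the step is a modest one. Among these compounds, with prop-1-en-1-yl held in place, ethyl in place of hydrogen on an oxygen next to a carbonyl group gives a 1.8-fold lower number from compound 1 to compound 3 (0.26 log units; within the scatter), so in this one setting the ester and the free carboxylic acid cannot be told apart, and of the two single changes only the one from vinyl to prop-1-en-1-yl lies beyond the scatter. Nothing available explains either step.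

Whether the ethyl-to-hydrogen change would also stay within the scatter with vinyl on the carbonyl carbon remains open, since a vinyl compound carrying the free carboxylic acid does not appear among those shown. Also open, from the compounds shown here alone, is how other groups on that carbonyl carbon, such as a saturated ethyl, a chloromethyl or a dimethylamino-bearing butenyl chain, would read against vinyl and prop-1-en-1-yl.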